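The compounds below may be only part of what the source reports. "The series", "measured", "known", "first", "only" and "open" are said of these compounds alone.

Two compounds already have numbers in an ADME assay on cells for inhibition of cytochrome P450 11B1, mitochondrial (Homo sapiens), read by HPLC, with a stated time of 60 min; a lower number here means a stronger inhibitor, a higher number a weaker inhibitor. Compound 1, with structure `Fc1ccc2nc(-c3cnccn3)n(C3CC3)c2c1`, reaches only a limit in this assay: compound 1 gives > 10000 nM, which is a bound of the measurement and not a number. Among the compounds with values here, compound 2, with structure `CCc1ncncc1-c1nc2cc(F)c(F)cc2n1C1CC1`, is the one compound with an actual value: in this assay compound 2 gives 3330 nM. So compound 2 stands alone as the only measured number, while the other entry sits at a limit, as seen in the limit of > 10000 nM in this assay, at which 1 of the 2 values shown sits.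

Compound 3, with structure `Fc1cc2nc(-c3cncnc3C(F)F)n(C3CC3)c2cc1F`, has not yet been measured. It is built from compound 2 by one change: difluoromethyl in place of ethyl on an aromatic carbon. Within the data shown here, no pair of measured compounds shows a step of this kind, so the expectation rests on the single value of compound 2 alone. The step is expected to be modest and within or only slightly beyond the usual scatter, with no firm direction. For compound 3 the estimated value in this assay is 2500 nM, in the range 800 nM to 8000 nM. This means an expected step of a 1.3-fold lower number from compound 2 to compound 3 (0.12 log units; within the scatter).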

Compound 3, half-maximal inhibitory concentration: 4330 nM
Estimate against measurement, compound 3: 1.7-fold (0.24 log units) below, within the range that was stated.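

Putting difluoromethyl in place of ethyl on this aromatic carbon gives a 1.3-fold higher number from compound 2 to compound 3 (0.11 log units; within the scatter) in this assay. This is the only step shown between two compounds that differ in one place, and it shows that these two groups cannot be told apart at this position, even though one carries two fluorine atoms and the other none. Compound 1 remains the one entry that is a limit and not a number: the limit of > 10000 nM in this assay, at which 1 of the 3 values shown sits.

A single step at a single position cannot show whether this carbon matters much for inhibition in this assay, since the two groups compared here give values within the scatter of each other. From the compounds shown here alone, it remains open how an amine, a carboxylic acid or a longer chain such as butyl would read at this carbon, and whether any group placed here could move the number beyond the scatter in either direction.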